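A few compounds are considered here, and "the series" means these few. Any claim that something is new, unique, unknown or untested is made for them only; others in the source may bear on it.

In a functional assay on CAL-27 cells (Homo sapiens) for cytotoxicity, read by MTT assay, with a stated time of 72 h (a lower number here means a stronger inhibitor, a higher number a weaker inhibitor), compound 2 `CC(C)(C(=O)NC1CCCCC1)N(CCCCCC(=O)NO)C(=O)c1ccccc1` gives 66900 nM and compound 3 `CN(C)c1ccc(C(=O)N(CCCCCC(=O)NO)C(C)(C)C(=O)NC2CCCCC2)cc1` gives 47700 nM. Placing dimethylamino on an aromatic carbon makes a 1.4-fold lower number from compound 2 to compound 3 (0.15 log units; within the scatter), so these two sit level. Compound 1 `CN(C)c1ccc(C(=O)N(CCCCCC(=O)NO)CC(=O)NC(C)(C)C)cc1` gives 4040 nM, a clearly lower number than either. Compound 4 `CC(C)(C)NC(=O)C(C)(C)N(CCCCCC(=O)NO)C(=O)c1ccccc1` is unmeasured and puts tert-butyl in place of cyclohexyl on an amide-type nitrogen of compound 2: tert-butyl in place of cyclohexyl on an amide-type nitrogen. Among the compounds with values here, no measured step makes this swap alone. Compound 1, at 4040 nM, also carries tert-butyl but differs from compound 4 elsewhere too, so it cannot size the swap. No shift beyond the scatter is therefore expected in this assay, and the estimated step is a 1.3-fold lower number from compound 2 to compound 4 (0.13 log units; within the scatter). The estimate for compound 4 is 50000 nM, with an expected range of 20000 nM to 110000 nM.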

Compound 4, half-maximal inhibitory concentration: 75800 nM
For compound 4 the middle estimate is 1.5-fold (0.18 log units) below the measured one, within the range that was stated.
By their numbers in this assay, from the lowest: compound 1; then compounds 3, 2 and 4 (each within the scatter of the next).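

In this assay the swap of cyclohexyl for tert-butyl on this amide-type nitrogen gives a 1.1-fold higher number from compound 2 to compound 4 (0.05 log units; within the scatter) and leaves the two compounds level. Within the data shown here, this is the first direct reading of the swap, and it shows that on the core of compound 2, a group without a ring and with fewer heavy atoms does as well here as cyclohexyl. No measurement at hand bears on this result.

Still open, on these data alone, is whether an amine or a carboxylic acid on this nitrogen would move the number. As far as these compounds go, the same swap on the core of compound 3, which carries dimethylamino, also remains open.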